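The source may hold more compounds than are shown below. What is called first, only, known or untested is meant among the compounds shown, and "the series" means these compounds.

Measured compounds:
compound 1 `N#CCCCn1c(Cn2c(=O)n(-c3ccncc3)c3ccncc32)cc2cc(Cl)ccc21` — > 50000 nM in an ADME assay on HeLa cells (Homo sapiens) for cytotoxicity, read by ATP content, with a stated time of 3 days; on this read-out lower numbers stand for higher toxicity in this test and higher numbers for lower toxicity in this test
compound 2 `COc1ccc(-n2c(=O)n(Cc3cc4cc(Cl)ccc4n3CCCC#N)c3cnccc32)cc1C` — > 50000 nM

In this assay compound 1 gives > 50000 nM, which is a limit of the assay and not a number. Compound 2 likewise gives > 50000 nM, again a limit rather than a number. Going by the values given here, the one measured step, a step that the two limits leave unreadable from compound 1 to compound 2, therefore cannot be read; compound 2 stands at the limit of > 50000 nM in this assay, at which 2 of the 2 values shown sit, with nothing to set it apart from compound 1.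

Compound 3 `Cc1ccc(-n2c(=O)n(Cc3cc4cc(Cl)ccc4n3CCCC#N)c3cnccc32)cc1` is not yet measured. It differs from compound 2 by 4-methylphenyl in place of 4-methoxy-3-methylphenyl on an aromatic nitrogen. Among the compounds with values here, no measured step bears on this change, and the only step recorded, a step that the two limits leave unreadable from compound 1 to compound 2, is itself unreadable. With both measured compounds sitting at the limit of > 50000 nM in this assay, at which 2 of the 2 values shown sit, compound 3 is expected to stay there as well, so the expected step that the limit leaves unreadable from compound 2 to compound 3 is none beyond the scatter. Compound 3 is estimated at 60000 nM, within 30000 nM to 150000 nM.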

Compound 3, half-maximal cytotoxic concentration: > 50000 nM
Compound 3 gave a limit, no number; the forecaster's own chance of this, stated with the estimate: 85%; the middle value is on the limit's open side.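

Compound 3 joins compound 1 and compound 2 at a limit of this assay rather than a number, so the steps among these three compounds cannot be read: the limit of > 50000 nM in this assay, at which 3 of the 3 values shown sit.

The compounds shown leave open whether any of these groups on the aromatic nitrogen changes toxicity in this assay at all.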